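Methylsulfonyl in Place of Methylsulfanyl: A Second Test

The source may report more compounds than this note shows. Statements on the series, on what has been measured and on what is new or still open speak of the compounds shown alone.

The measure here is a functional assay for agonist activity at Alpha-1B adrenergic receptor (Homo sapiens); a lower number here means that less compound is needed, a higher number that more compound is needed for the effect. Compound 1, `CSc1c(F)cccc1NCC1=NCCN1`, gives 85.1 nM in this assay. Compound 2, `CS(=O)(=O)c1c(F)cccc1NCC1=NCCN1`, differs from it by methylsulfonyl in place of methylsulfanyl on an aromatic carbon. For compound 2 this assay reports only a limit, < 100000 nM, not a number. The step that the limit leaves unreadable from compound 1 to compound 2 therefore cannot be read in size; what is known is the limit of < 100000 nM in this assay, at which 1 of the 3 values shown sits.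

Compound 3, `CSc1ccc(C(F)(F)F)cc1NCC1=NCCN1`, gives 6.03 nM in this assay, the lowest number among the measured compounds, and its gap to compound 1 lies beyond the usual scatter. How the core of compound 3 differs from the core of compound 1 is not broken down here.

Compound 4, `CS(=O)(=O)c1ccc(C(F)(F)F)cc1NCC1=NCCN1`, has not been measured. It differs from compound 3 by methylsulfonyl in place of methylsulfanyl on an aromatic carbon. Among the compounds with values here, this is the same kind of change as the one from compound 1 to compound 2, but the surroundings differ: in compound 1 the changed carbon sits ortho to a fluoro group and ortho to a group of 7 heavy atoms, whereas in compound 3 it sits ortho to a group of 7 heavy atoms and para to a trifluoromethyl group.

The step from compound 3 to compound 4 is expected to weaken activity, and a 500-fold higher number from compound 3 to compound 4 (2.70 log units; beyond the scatter) is the estimated size, resting on the fact that compound 2 reached only a limit at < 100000 nM. For compound 4 the expected value in this assay is 3000 nM, with a likely range from 300 nM to 50000 nM.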

Compound 4, half-maximal effective concentration: < 100000 nM
Compound 4 ended at the assay's limit; the forecaster's own chance of this, stated with the estimate: 30%; the middle value does not contradict the limit.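

In this assay compound 4 gives only a limit, < 100000 nM, and not a number. Within the data shown here, the size of the step from compound 3 to compound 4 therefore cannot be read, any more than the one from compound 1 to compound 2. Still open, on these data alone, is how large this change really is in each case, and whether its size differs between the two surroundings.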